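The compounds below may be only part of what the source reports. "The series", "measured", "known", "first", "only" and "open" are said of these compounds alone.

Measured so far in an ADME assay for inhibition of Amine oxidase [flavin-containing] A (Homo sapiens), read by luminescence, with a stated time of 1 h; on this read-out higher numbers stand for weaker inhibition and lower numbers for stronger inhibition:
compound 1 `CC(=O)NC[C@H]1CN(c2ccc(N3C=CC(=O)CC3)c(F)c2)C(=O)O1`: 3.8 ug/mL
compound 2 `CC(=O)NC[C@H]1CN(c2cc(F)c(N3C=CC(=O)CC3)c(F)c2F)C(=O)O1`: 56.9 ug/mL
compound 3 `COC(=O)NC[C@H]1CN(c2cc(F)c(N3C=CC(=O)CC3)c(F)c2F)C(=O)O1`: 24.4 ug/mL

Compound 3 gives the second highest of the three numbers; compound 2 sits nearest with a higher number and compound 1 furthest with a lower one. Compound 4 `O=C1C=CN(c2c(F)cc(N3C[C@H](Cn4ccnn4)OC3=O)c(F)c2F)CC1` differs from compound 3 by 1H-1,2,3-triazol-1-yl in place of (methoxycarbonyl)amino on a saturated chain carbon bound to a saturated ring carbon. Among the compounds with values here, the only measured step at this part of the molecule, a 2.3-fold lower number from compound 2 to compound 3 (0.37 log units; beyond the scatter), was modest, and it exchanged only the group on the carbonyl carbon rather than replacing the whole substituent, so it bears on the new step loosely at best. Within the data shown here, compound 1 and compound 2 differ elsewhere, and no step is given for that pair. The change into compound 4 is therefore expected to be small in this assay, with wide uncertainty in either direction, the estimated step being a 1.2-fold lower number from compound 3 to compound 4 (0.09 log units; within the scatter). Compound 4 is expected to give 20 ug/mL, within a range from 7 ug/mL to 60 ug/mL.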

Compound 4, half-maximal inhibitory concentration: > 100 ug/mL
Compound 4: no number, only a limit; the forecaster's own chance of this, stated with the estimate: 10%; middle value at least 5.0-fold (0.69 log units) away from the limit.
By their numbers in this assay, from the lowest: compound 1; then compound 3; then compound 2. At a limit, above all of these: compound 4.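

The reading for compound 4 in this assay is a limit of the assay and not a number: the limit of > 100 ug/mL in this assay, at which 1 of the 4 values shown sits. Putting 1H-1,2,3-triazol-1-yl in place of (methoxycarbonyl)amino gives an at least 4.0-fold higher number from compound 3 to compound 4 (0.61 log units; beyond the scatter), so replacing the whole substituent at this position moves the read-out toward weaker inhibition. Against acetamido the step is an at least 1.7-fold higher number from compound 2 to compound 4 (0.24 log units; that floor lies within the scatter), so that comparison fixes no order on its own.

From the compounds shown here alone, how far the true value of compound 4 lies past its limit stays open. Also open, going by these compounds, is whether an amine or a hydroxyl on this carbon would give the same shift, and whether the step holds on the core of compound 1.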